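Sulfo on the Primary Oxygen: A Step Without a Baseline

The compounds below may be only part of what the source reports. "The series", "measured", "known", "first", "only" and "open" are said of these compounds alone.

Measured so far:
compound 1 `C=CCCC(=O)N[C@H]1[C@@H](OCCc2ccccc2)O[C@H](CO)[C@@H](O)[C@@H]1O` gives > 50 uM
compound 2 `C=CCCC(=O)N[C@H]1[C@@H](OCCc2ccccc2)O[C@H](CO)[C@@H](O)[C@@H]1OS(=O)(=O)O` gives > 50 uM

The account concerns two measured compounds and one that is not yet measured, all sharing one core. In a functional assay on C6 cells (Rattus norvegicus), read by thymidine incorporation (on this read-out lower numbers stand for stronger inhibition and higher numbers for weaker inhibition), compound 1 gives > 50 uM, which is a limit of the assay and not a number. In this assay compound 2 gives > 50 uM, again a limit. For the measured compounds named here, the one measured step, a step that the two limits leave unreadable from compound 1 to compound 2, therefore tells nothing about direction or size, and the only evidence on hand is the limit of > 50 uM in this assay, at which 2 of the 2 values shown sit.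

Compound 3 `C=CCCC(=O)N[C@H]1[C@@H](OCCc2ccccc2)O[C@H](COS(=O)(=O)O)[C@@H](O)[C@@H]1O` differs from compound 1 by sulfo in place of hydrogen on an oxygen on a saturated carbon. Going by the values given here, no measured step shows what this change does; the only comparison available, that between compound 1 and compound 2, is unreadable because both sit at the limit of > 50 uM in this assay, at which 2 of the 2 values shown sit. Among the compounds with values here, with compound 1 standing at the limit, the expectation for compound 3 is simply that it remains in the same region, the estimated step that the limit leaves unreadable from compound 1 to compound 3 being no step that can be read. Compound 3 is therefore expected to give about 80 uM in this assay, within a range of 20 uM to 300 uM, most probably reported again as a limit.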

Compound 3, concentration for 50% inhibition: > 50 uM
Compound 3: no number, only a limit; the forecaster's own chance of this, stated with the estimate: 80%; the middle value lies beyond the limit too.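

No new step can be read, since compound 1 and compound 3 both stand at a limit and not at a number, which leaves the change between them unreadable: the limit of > 50 uM in this assay, at which 3 of the 3 values shown sit.

The compounds shown leave open whether, and how strongly, any of the three inhibits in this assay, and whether sulfo in place of hydrogen changes that in either direction.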